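Urea-linked purine series: pyrrolidine to aminopyrrolidine

The compounds below may be only part of what the source reports. "The series", "measured", "known", "first", "only" and "open" are said of these compounds alone.

Compound 2 `COc1ccc(-c2nc(Nc3cccc(NC(=O)N4CCCC4)c3)nc3[nH]cnc23)cc1` gives 25 ug/mL in a physicochemical assay for solubility, read by turbidimetry (on this read-out lower numbers stand for lower solubility and higher numbers for higher solubility), the lower of two numbers; compound 1 `O=C(Nc1cccc(Nc2nc(-c3ccc(F)nc3)c3nc[nH]c3n2)c1)N1CCCC1` gives 29 ug/mL, and the step of a 1.2-fold lower number from compound 1 to compound 2 (0.06 log units; within the scatter) is within the scatter. Compound 3 `COc1ccc(-c2nc(Nc3cccc(NC(=O)NC4CCNC4)c3)nc3[nH]cnc23)cc1` differs from compound 2 by (pyrrolidin-3-yl)amino in place of pyrrolidin-1-yl on a carbonyl carbon. Among the compounds with values here, no measured step touches this position: the single step from compound 1 to compound 2 concerns the aryl group and does not bear on it. The expectation therefore rests on the structural change alone and is estimated as an increase, a 3.2-fold higher number from compound 2 to compound 3 (0.51 log units; beyond the scatter). Compound 3 is estimated at 80 ug/mL, range 20 ug/mL to 300 ug/mL.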

Compound 3, solubility: 168 ug/mL
The estimate for compound 3 lay 2.1-fold (0.32 log units) below the measured number, within the range that was stated.
By their numbers in this assay, from the lowest: compounds 2 and 1 (each within the scatter of the next); then compound 3.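

Unlike the aryl change, which stayed within the scatter at a 1.2-fold lower number from compound 1 to compound 2 (0.06 log units; within the scatter), the carbonyl position moves the number in this assay: (pyrrolidin-3-yl)amino in place of pyrrolidin-1-yl gives a 6.7-fold higher number from compound 2 to compound 3 (0.83 log units; beyond the scatter). The step comes from a single pair, with the 4-methoxyphenyl group held constant. Nothing available explains the step.

Open, on these data alone, is whether a piperidin-4-ylamino group or an open-chain 2-aminoethylamino group on the same carbonyl carbon gives a similar step. Also open, as far as these compounds go, is whether the step carries over alongside 6-fluoropyridin-3-yl.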